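Cyclopropyl for ethyl on the amide of compound 2

The source may hold more compounds than are shown below. What is called first, only, known or untested is meant among the compounds shown, and "the series" means these compounds.

Measured so far:
Compound 1, `CCCC(=O)NCCCc1cccc2c1C[C@@H](CCCCc1ccccc1)O2`: 30 nM
Compound 2, `CCC(=O)NCCCc1cccc2c1C[C@@H](CCCCc1ccccc1)O2`: 20 nM
Compound 3, `CC(C)C(=O)NC[C@@H]1C[C@H]1c1cccc2c1C[C@@H](CCCCc1ccccc1)O2`: 90 nM

All three were tested in an assay on NIH3T3 cells for binding affinity to melatonin receptor type 1B (Homo sapiens); on this read-out higher numbers stand for weaker inhibition and lower numbers for stronger inhibition. Compound 2 gives the lowest number of the three; compound 1 stands a 1.5-fold lower number from compound 1 to compound 2 (0.18 log units; within the scatter) away, a difference within the scatter, so the two cannot be ranked. Compound 3 lies further off, at a gap beyond the scatter, but it differs from compound 2 in the chain as well as in the amide group, so no single change explains it.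

Compound 4, `O=C(NCCCc1cccc2c1C[C@@H](CCCCc1ccccc1)O2)C1CC1`, is not yet measured. It differs from compound 2 by cyclopropyl in place of ethyl on a carbonyl carbon. Among the compounds with values here, the only measured step at this position is the one from compound 1 to compound 2, which stayed within the scatter. The change to a cyclopropyl is of a similar kind, a small alteration on the carbonyl carbon, so no step beyond the scatter is expected in this assay. Compound 4 is therefore estimated at 25 nM, ranging from 10 nM to 60 nM, which would be a step of a 1.3-fold higher number from compound 2 to compound 4 (0.10 log units; within the scatter).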

Compound 4, inhibition constant: 30 nM
Beside the measured number, compound 4's estimate is 1.2-fold (0.08 log units) below it, and the stated range covers the measured number.
By their numbers in this assay, from the lowest: compounds 2, 1 and 4 (each within the scatter of the next); then compound 3.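

In this assay the change from ethyl to cyclopropyl on the carbonyl carbon gives a 1.5-fold higher number from compound 2 to compound 4 (0.18 log units; within the scatter) and the change from propyl to cyclopropyl gives no change at the digits printed from compound 1 to compound 4 (within the scatter) as well. The earlier single-place comparison covered only two open chains, whereas these steps show that a three-membered ring of carbon only can stand at this position with no step beyond the scatter, so compounds 1, 2 and 4 cannot be ranked. Nothing available explains why the ring and the two chains read alike.

The compounds shown leave open how a larger ring such as cyclohexyl or phenyl would read on this carbonyl carbon in this assay and whether a longer chain would stay within the scatter. They also leave open whether an amine at this place would do the same.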